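Triazole hydroxamates: where compound 2 stands and what follows

The source may hold more compounds than are shown below. What is called first, only, known or untested is meant among the compounds shown, and "the series" means these compounds.

Measured so far:
- compound 1, `O=C(NO)c1ccc(NCc2nc(-c3cccs3)nn2-c2ccc(O)cc2)cc1`: 33.5 nM
- compound 2, `COc1ccc(-c2nc(CNc3ccc(C(=O)NO)cc3)n(-c3ccccc3)n2)cc1`: 163 nM
- compound 3, `O=C(NO)c1ccc(NCc2nc(-c3ccccc3)nn2-c2ccccc2Cl)cc1`: 669 nM

The read-out is an assay on Sf9 cells for inhibition of protein deacetylase HDAC6 (Homo sapiens), read by fluorescence, with a stated time of 40 min; on this read-out lower numbers stand for stronger inhibition and higher numbers for weaker inhibition. Compound 2 stands second highest of the three numbers: compound 3 lies at a higher number, beyond the scatter, and compound 1 at a lower number, also beyond the scatter. Compound 1 and compound 3 differ from compound 2 in more than one place, so their gaps cannot be tied to any single change.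

The next compound is compound 4, `O=C(NO)c1ccc(NCc2nc(-c3cccc(Cl)c3)nn2-c2ccccc2)cc1`. It differs from compound 2 in one place: 3-chlorophenyl in place of 4-methoxyphenyl on an aromatic carbon. The aromatic group on the ring nitrogen is the same in compound 2 and compound 4, so the only thing to read is the swap of the 4-methoxyphenyl for the 3-chlorophenyl. Among the measured compounds shown here, no measured pair shows this swap alone, so there is no step to lean on.

The step from compound 2 to compound 4 is expected to be a 1.2-fold higher number from compound 2 to compound 4 (0.09 log units; within the scatter), which is to say no clear shift beyond the scatter in either direction. For compound 4 the expected value in this assay is 200 nM, with a range from 60 nM to 700 nM.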

Compound 4, half-maximal inhibitory concentration: 115 nM
Beside the measured number, compound 4's estimate is 1.7-fold (0.24 log units) above it, within the range that was stated.
By their numbers in this assay, from the lowest: compound 1; then compounds 4 and 2 (each within the scatter of the next); then compound 3.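

In this assay, the change from 4-methoxyphenyl to 3-chlorophenyl gives a 1.4-fold lower number from compound 2 to compound 4 (0.15 log units; within the scatter). Among the compounds shown here, this is the first reading of a single change: on this aromatic carbon, between two ring nitrogen atoms, the hydrogen-bond acceptor of 4-methoxyphenyl is lost and a chlorine enters at a different ring position, with no shift beyond the scatter. No measurement at hand offers an explanation for this result.

Compound 1 and compound 3 each differ from compound 2 and compound 4 in more than one place, and those gaps cannot be read. For the compounds shown here, it remains open whether this position stays as unresponsive when the aromatic ring carries an amine or a carboxylic acid, since only this one pair of aryl groups has been compared there.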